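Swapping Chloro for Methyl on the Sulfonyl Aryl Ring

This account rests on a few compounds, and the source may have more. Where it says the series, first, only, none or still open, it means among the compounds named here.

Compound 1 `O=S(=O)(c1ccc(Cl)cc1)N1N=C2CCCCC2C1c1ccc(Cl)cc1` gives 5.9 in a physicochemical assay for lipophilicity, measured as octanol-water partition; a lower number here means a more polar compound, a higher number a more lipophilic compound. Compound 2 `Cc1ccc(S(=O)(=O)N2N=C3CCCCC3C2c2ccc(Cl)cc2)cc1` differs from it by methyl in place of chloro on an aromatic carbon; in this assay compound 2 gives 5.8, so that a number 0.10 log units lower from compound 1 to compound 2 (within the scatter). Compound 3 `COc1ccc(C2C3CCCCC3=NN2S(=O)(=O)c2ccc(Cl)cc2)cc1` carries a different core, set apart from compound 1 by methoxy in place of chloro on an aromatic carbon; in this assay compound 3 gives 4.3, and a number 1.60 log units lower from compound 1 to compound 3 (beyond the scatter). Compound 4 `COc1ccc(C2C3CCCCC3=NN2S(=O)(=O)c2ccc(C)cc2)cc1` has not yet been measured. Compound 4 differs from compound 3 by methyl in place of chloro on an aromatic carbon, the same change that turns compound 1 into compound 2, made at the same place. Since a number 0.10 log units lower from compound 1 to compound 2 (within the scatter) stayed within the scatter, only a small shift is expected here as well. The expected step is a number 0.10 log units lower from compound 3 to compound 4 (within the scatter). For compound 4 the estimate is 4.2, within a range from 3.6 to 4.8.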

Compound 4, partition coefficient: 5.1
Estimate against measurement, compound 4: 0.90 log units below; the whole stated range lies below it.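

The swap of methyl for chloro did not carry over from one core to the other: in this assay it gave a number 0.10 log units lower from compound 1 to compound 2 (within the scatter), but a number 0.80 log units higher from compound 3 to compound 4 (beyond the scatter). The companion swap of methoxy for chloro moved the same way in both pairs, with a number 1.60 log units lower from compound 1 to compound 3 (beyond the scatter) and a number 0.70 log units lower from compound 2 to compound 4 (beyond the scatter). These four compounds show that the effect of the change depends on its surroundings in this series, but nothing measured here explains that dependence.

The compounds shown leave open how this swap would behave on any further core. They also leave open what an amine, a carboxylic acid or a longer chain would do in place of the chloro.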